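Replacing the amino group of compound 3 with methoxy

A few compounds are considered here, and "the series" means these few. Any claim that something is new, unique, unknown or untested is made for them only; others in the source may bear on it.

Values measured so far in a physicochemical assay for solubility, at pH 7.4; on this read-out higher numbers stand for higher solubility and lower numbers for lower solubility:
Compound 1 `CC(=O)c1ccc(NC(=O)Nc2cc(C)nc3ccccc23)cc1` gives 3800 nM
Compound 2 `COC(=O)c1ccc(NC(=O)Nc2cc(C)nc3ccccc23)cc1` gives 1200 nM
Compound 3 `Cc1cc(NC(=O)Nc2ccc(N)cc2)c2ccccc2n1` gives 18500 nM

Compound 3 holds the highest number of the three. For the measured compounds named here, compound 4 `COc1ccc(NC(=O)Nc2cc(C)nc3ccccc23)cc1` has not been measured and carries methoxy in place of amino on an aromatic carbon as its only change. Two measured steps put amino in place of another group on an aromatic carbon: acetyl in a 4.9-fold higher number from compound 1 to compound 3 (0.69 log units; beyond the scatter) and methoxycarbonyl in a 15-fold higher number from compound 2 to compound 3 (1.19 log units; beyond the scatter) as the second case. Going by the values given here, no measured compound carries methoxy there, so the guidance is loose. Both times the amino compound held the higher number, so a modest drop in this assay is expected. The expected change is a 4.6-fold lower number from compound 3 to compound 4 (0.67 log units; beyond the scatter) in this estimate. Compound 4 is estimated at 4000 nM (expected range 1200 nM to 12000 nM).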

Compound 4, solubility: 19800 nM
Compound 4: middle estimate off by 5.0-fold (0.69 log units), on the low side, and the stated range ends below it.
By their numbers in this assay, from the lowest: compound 2; then compound 1; then compounds 3 and 4 (each within the scatter of the next).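

In this assay methoxy on this aromatic carbon matches amino, with a 1.1-fold higher number from compound 3 to compound 4 (0.03 log units; within the scatter) and thus no real change. The high numbers are therefore not tied to amino: methoxy, with 0 hydrogen-bond donors, also shows a 5.2-fold higher number from compound 1 to compound 4 (0.72 log units; beyond the scatter) against acetyl and a 17-fold higher number from compound 2 to compound 4 (1.22 log units; beyond the scatter) against methoxycarbonyl. Nothing available explains why these groups differ or why amino and methoxy match. Still open, going by these compounds, is whether a carboxylic acid, a dimethylamino group or a longer chain such as ethoxy at this position would stay level with amino and methoxy or fall toward acetyl and methoxycarbonyl.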